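A Hydroxy-Methoxy Variant of Compound 1

The source may hold more compounds than are shown below. What is called first, only, known or untested is meant among the compounds shown, and "the series" means these compounds.

Compound 1 `COc1ccc(OC)c(/C=N/NC(=O)Nc2ccc(Oc3ccnc(-c4nncn4CCN(C)C)c3)c(F)c2)c1` gives 2070 nM in a functional assay on HT-29 cells (Homo sapiens) for cytotoxicity, read by MTT assay, with a stated time of 72 h (on this read-out lower numbers stand for stronger inhibition and higher numbers for weaker inhibition), the highest of the three numbers measured. Compound 2 `CN(C)CCn1cnnc1-c1cc(Oc2ccc(NC(=O)N/N=C/c3ccccc3O[N+](=O)[O-])cc2F)ccn1` gives 950 nM and compound 3 `CN(C)CCn1cnnc1-c1cc(Oc2ccc(NC(=O)N/N=C/c3ccc(O)c(O)c3)cc2F)ccn1` gives 1890 nM. Within the data shown here, the only step beyond the scatter is a 2.2-fold lower number from compound 1 to compound 2 (0.34 log units; beyond the scatter); the step of a 1.1-fold lower number from compound 1 to compound 3 (0.04 log units; within the scatter) stays within it, as does a 2.0-fold higher number from compound 2 to compound 3 (0.30 log units; within the scatter). Compound 4 `COc1ccc(/C=N/NC(=O)Nc2ccc(Oc3ccnc(-c4nncn4CCN(C)C)c3)c(F)c2)cc1O` differs from compound 1 in one place: 3-hydroxy-4-methoxyphenyl in place of 2,5-dimethoxyphenyl on a carbon with a double bond to nitrogen. The step of a 1.1-fold lower number from compound 1 to compound 3 (0.04 log units; within the scatter) is the closest guide, both changes putting a hydroxy group on that ring, and it was within the scatter. No step beyond the scatter is therefore expected, the estimated step being a 1.2-fold lower number from compound 1 to compound 4 (0.06 log units; within the scatter). Compound 4 is expected to give 1800 nM, with a range from 900 nM to 3600 nM.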

Compound 4, half-maximal inhibitory concentration: 960 nM
Estimate against measurement, compound 4: 1.9-fold (0.27 log units) above, within the range that was stated.
By their numbers in this assay, from the lowest: compounds 2, 4, 3 and 1 (each within the scatter of the next, the first and the last beyond it).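

In this assay, 3-hydroxy-4-methoxyphenyl in place of 2,5-dimethoxyphenyl gave a 2.2-fold lower number from compound 1 to compound 4 (0.33 log units; beyond the scatter), so a ring carrying a hydroxy group can clear the scatter at this carbon, though compound 3 did not. Methyl in place of hydrogen on that ring oxygen gave a 2.0-fold lower number from compound 3 to compound 4 (0.29 log units; within the scatter), and replacing 2-(nitrooxy)phenyl gave a 1.0-fold higher number from compound 2 to compound 4 (0.00 log units; within the scatter), leaving compound 4 unresolved from both compound 3 and compound 2. Nothing measured here explains these steps. Going by these compounds, whether an amine or a carboxylic acid on this ring would shift the number remains open, as does the effect of a longer chain on its oxygen.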